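This account rests on a few compounds, and the source may have more. Where it says the series, first, only, none or still open, it means among the compounds named here.

Compound 1 `C=CC(=O)Nc1ncc(-c2ccccc2)s1`: > 30000 nM
Compound 2 `C=CC(=O)N(Cc1ccccc1)c1nc(-c2ccccc2)cs1`: > 30000 nM

Both compounds were tested in a functional assay on HCT-116 cells (Homo sapiens) for antiproliferative activity, read by MTT assay, with a stated time of 72 h; on this read-out lower numbers stand for stronger inhibition and higher numbers for weaker inhibition. Neither entry is a true number, since each is a limit of the assay. Compound 2 stands at the limit of > 30000 nM in this assay, at which 2 of the 2 values shown sit. Going by the values given here, no measured potency is therefore available as a starting point, and no step between two measured compounds can be read from these results.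

Compound 3 `C=CC(=O)N(CC(=O)OC(C)(C)C)c1nc(-c2ccccc2)cs1` keeps the core of compound 2 and changes a single group: tert-butoxycarbonyl in place of phenyl on a saturated chain carbon bound to an amide-type nitrogen. Put another way, benzyl gives way to (tert-butoxycarbonyl)methyl, so the phenyl ring leaves and an open chain enters.

No step beyond the usual scatter is expected in this assay, in either direction. This expectation rests on compound 2, whose reading of > 30000 nM is a limit. The estimated size of the change is a number no higher from compound 2 to compound 3 (the limit leaves the size open). The estimate for compound 3 is 30000 nM, with an expected range of 10000 nM to 60000 nM. The assay may well report only a limit again.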

Compound 3, half-maximal inhibitory concentration: 20900 nM
The estimate for compound 3 lay 1.4-fold (0.16 log units) above the measured number, and the stated range covers the measured number.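

In this assay compound 3 gives 20900 nM as the first true number among the compounds shown, so a reading inside the range of the assay is possible at this place, a saturated chain carbon bound to an amide-type nitrogen, with tert-butoxycarbonyl in place of phenyl. Compound 2 stands at > 30000 nM here, and that entry is a limit, not a number. The change reads as an at least 1.4-fold lower number from compound 2 to compound 3 (0.15 log units; that floor lies within the scatter) and only this floor is known, because compound 2 offers no number of its own to measure from: the limit of > 30000 nM in this assay, at which 2 of the 3 values shown sit.

The compounds shown leave open whether the reading depends on tert-butoxycarbonyl itself or on the phenyl ring having left, and a carboxylic acid, a primary amide or a plain ethyl chain at the same place would help to tell these apart. They also leave open how large the true step from benzyl to (tert-butoxycarbonyl)methyl is, since one end of it is only a limit.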